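Replacing 4-(diethylamino)phenyl on a compound at the assay limit

A few compounds are considered here, and "the series" means these few. Any claim that something is new, unique, unknown or untested is made for them only; others in the source may bear on it.

Measured so far in a functional assay on HOS-TE85 cells (Homo sapiens) for inhibition, read by CCK-8 assay, with a stated time of 72 h (a lower number here means a stronger inhibitor, a higher number a weaker inhibitor), for two compounds:
Compound 1 (`CCN(CC)c1ccc(N2C(=O)CSC2c2cccc(C(=O)NCCCCc3ccccc3)c2)cc1`) gives > 1000 nM as a limit
Compound 2 (`COc1ccccc1N1C(=O)CSC1c1cc(C(=O)NCCCCc2ccccc2)cc(C2CC2)c1`) gives 23.5 nM as a number

In this assay compound 1 gives > 1000 nM and this is a limit of the assay, not a number. Compound 1 therefore stands at the limit of > 1000 nM in this assay, at which 1 of the 2 values shown sits, and has no exact value to start from.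

The next compound is compound 3 (`O=C(NCCCCc1ccccc1)c1cccc(C2SCC(=O)N2c2cccc(-c3c[nH]nn3)c2)c1`). It loses the 4-(diethylamino)phenyl on an amide-type nitrogen in a ring and gains a group holding a five-membered aromatic ring with 3 hetero atoms and a six-membered aromatic ring of carbon only: a group of 11 heavy atoms (8 carbon, 3 nitrogen; one five-membered aromatic ring with 3 hetero atoms, one six-membered aromatic ring of carbon only) in place of a group of 11 heavy atoms (10 carbon, 1 nitrogen; one six-membered aromatic ring of carbon only), on an amide-type nitrogen in a ring is the full count.

Among the measured compounds shown here, no measured step covers this change. Compound 2 reads 23.5 nM in this assay and so shows that a related structure can give a low number. A move toward stronger inhibition is expected, though of uncertain size, and compound 3 may yet stay at the limit. The expected change is an at least 3.3-fold lower number from compound 1 to compound 3 (0.52 log units; beyond the scatter) as estimated here. For compound 3 the estimated value is 300 nM with an expected range from 40 nM to 2000 nM in this estimate.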

Compound 3, half-maximal inhibitory concentration: 110 nM
Estimate against measurement, compound 3: 2.7-fold (0.44 log units) above, and the stated range covers the measured number.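

Compound 1 gives > 1000 nM in this assay, and this is a limit of the assay, not a number. On the amide-type nitrogen in a ring, replacing 4-(diethylamino)phenyl with the group holding a five-membered aromatic ring with 3 hetero atoms and a six-membered aromatic ring of carbon only, while the heavy-atom count stays the same and the rest of the core is unchanged, gives an at least 9.0-fold lower number from compound 1 to compound 3 (0.95 log units; beyond the scatter), which shows that this position can take a group that moves the compound off the limit. Because the step starts from a limit, its size is only a lower bound and the full gain remains unknown: the limit of > 1000 nM in this assay, at which 1 of the 3 values shown sits.

The compounds shown leave open how much of the step belongs to the five-membered ring, as they do not show what an unsubstituted phenyl on that nitrogen, or a phenyl carrying a carboxylic acid or an amine in place of that ring, would give. Compound 2 differs from compound 1 and compound 3 in more than one place, so steps to it cannot be read.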